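A few compounds are considered here, and "the series" means these few. Any claim that something is new, unique, unknown or untested is made for them only; others in the source may bear on it.

Compound 1 `COc1cc(C(=O)Nn2ccnc2NCc2ccc(-c3cc(Cl)cc(F)c3-c3noc(C)n3)cc2F)on1` and compound 2 `COC(=O)c1c(F)cccc1-c1ccc(CN2CCCC2=O)c(F)c1` were both run in a functional assay on IMR-90 cells for antagonist activity at B1 bradykinin receptor (Homo sapiens), read by calcium flux; a lower number here means a stronger inhibitor, a higher number a weaker inhibitor. In this assay compound 1 gives 1.7 nM, while compound 2 gives 42000 nM, the higher of the two numbers, with a gap to compound 1 that lies far beyond the scatter. Compound 3 `COC(=O)c1c(F)cccc1-c1ccc(CNC(C)=O)c(F)c1` carries acetamido in place of 2-oxopyrrolidin-1-yl on a saturated chain carbon bound to an aromatic carbon, and it has not yet been measured in this assay. Going by the values given here, no step between measured compounds covers this change, so the expectation rests on compound 2 alone, whose value of 42000 nM already sits at the weak end of what the assay resolves. The expected step is a 1.4-fold higher number from compound 2 to compound 3 (0.15 log units; within the scatter), small and not beyond the scatter, leaning if anything toward a higher number. Compound 3 is therefore expected to give 60000 nM in this assay, within a range from 15000 nM to 200000 nM.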

Compound 3, half-maximal inhibitory concentration: 35000 nM
Compound 3: middle estimate off by 1.7-fold (0.23 log units), on the high side; the measured number falls inside the stated range.
By their numbers in this assay, from the lowest: compound 1; then compounds 3 and 2 (each within the scatter of the next).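

Going by these compounds alone, the step from the 2-oxopyrrolidin-1-yl group to acetamido gives a 1.2-fold lower number from compound 2 to compound 3 (0.08 log units; within the scatter) in this assay and is the first direct reading of a change at this place, on a saturated chain carbon bound to an aromatic carbon. The change removes the five-membered ring and adds a hydrogen-bond donor, yet the two compounds cannot be told apart in this read-out, so on this core neither the ring nor the missing donor is shown to matter. No measurement at hand explains this flat result.

The compounds shown leave open whether an amine, a carboxylic acid or a longer chain at this place would move the number beyond the scatter. They also leave open whether the same exchange would count for as little on a core that reads far lower.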